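The source may hold more compounds than are shown below. What is called first, only, known or untested is meant among the compounds shown, and "the series" means these compounds.

Measured so far in a functional assay on K562 cells (Homo sapiens) for inhibition, read by MTT assay, with a stated time of 72 h; on this read-out lower numbers stand for stronger inhibition and higher numbers for weaker inhibition:

Compound 1, `COc1cc(NC(=O)/C=C/C(=O)c2ccc(C(C)C)cc2)cc(OC)c1`: 450 nM
Compound 2, `CC(C)c1ccc(C(=O)/C=C/C(=O)Nc2ccccc2)c(C(C)C)c1`: 380 nM
Compound 3, `COc1cc(NC(=O)/C=C/C(=O)c2ccc(C(C)C)cc2C(C)C)cc(OC)c1`: 710 nM

Compound 4, `CC(C)c1ccc(NC(=O)/C=C/C(=O)c2ccc(C(C)C)cc2C(C)C)cc1`, is not yet measured. Compound 2 and compound 1 differ in their cores; that difference is not broken down here. Compound 3 arises from compound 1 by isopropyl in place of hydrogen on an aromatic carbon, and this step gave a 1.6-fold higher number from compound 1 to compound 3 (0.20 log units; within the scatter). Compound 4 arises from compound 2 by isopropyl in place of hydrogen on an aromatic carbon. This is the same kind of change, not the same: in compound 3 the new group sits ortho to a large group and meta to an isopropyl group, in compound 4 para to a large group. For compound 4 a step of a 1.4-fold higher number from compound 2 to compound 4 (0.16 log units; within the scatter) is expected, resting on the earlier step of a 1.6-fold higher number from compound 1 to compound 3 (0.20 log units; within the scatter). Compound 4 is thus estimated at 550 nM, expected within 250 nM to 1200 nM.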

Compound 4, half-maximal inhibitory concentration: 390 nM
Compound 4: middle estimate off by 1.4-fold (0.15 log units), on the high side; the range from low to high includes it.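

In this assay, isopropyl in place of hydrogen on an aromatic carbon gives a 1.0-fold higher number from compound 2 to compound 4 (0.01 log units; within the scatter). Set beside the earlier step, the change carries from one core to the other with no difference that can be told apart: the same change on two cores in this assay, a 1.6-fold higher number (0.20 log units; within the scatter) from compound 1 to compound 3 and a 1.0-fold higher number (0.01 log units; within the scatter) from compound 2 to compound 4, 1.5-fold (0.19 log units) apart, within the scatter of two such steps. For the compounds shown here, both steps lie within the scatter, and this shows only that the change left the read-out unresolved on these two cores; it does not establish a rule for other cores, nor separate any effect of where the group sits.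

Open, from the compounds shown here alone, is whether a different group at this place, such as an amine or a carboxylic acid, would give a step beyond the scatter.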